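A few compounds are considered here, and "the series" means these few. Any claim that something is new, unique, unknown or untested is made for them only; others in the source may bear on it.

Working notes on the series. Compound 1 `Cc1cccc(Cn2c(CN3CCN(C(=O)c4ccc(Br)cc4)CC3)nc3ccccc32)c1` gives 25.8% in an assay on isolated protein for inhibition of aldehyde dehydrogenase 1A1 (Homo sapiens), read by spectrophotometry, tested at 10 uM; a higher number here means more inhibition at the concentration tested (going by the name of the read-out), a lower number less inhibition. Compound 2 `O=C(C1CC1)N1CCN(Cc2nc3ccccc3n2Cc2ccc(F)cc2)CC1` gives 32.7% in this assay; the two values lie within the usual scatter of each other, so neither compound is separated from the other on these numbers. Compound 3 `CCCC(=O)N1CCN(Cc2nc3ccccc3n2Cc2cccc(C)c2)CC1` differs from compound 1 by propyl in place of 4-bromophenyl on a carbonyl carbon. Going by the values given here, no pair of measured compounds shows this change, so the step is estimated from the two values only; the step from compound 1 to compound 3 is expected to be a number 4.2 percentage points higher from compound 1 to compound 3 (within the scatter), not beyond the scatter in either direction. Compound 3 is therefore estimated at 30%, expected to fall between 12% and 48%.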

Compound 3, a percentage reported as inhibition, at one concentration (the size of the read-out at that concentration, not a potency): 79.1%
Beside the measured number, compound 3's estimate is 49.1 percentage points below it, and the stated range ends below it.
By their numbers in this assay, from the lowest: compounds 1 and 2 (each within the scatter of the next); then compound 3.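

Propyl in place of 4-bromophenyl on a carbonyl carbon gives, in this assay, a number 53.3 percentage points higher from compound 1 to compound 3 (beyond the scatter), so this position clearly affects the read-out. The change removes the aromatic ring and the bromine together, and this single pair cannot separate the two. Nothing at hand bears on the reason for the step.

Still open, on these data alone, is whether unsubstituted phenyl, which would keep the ring without the bromine, stays near compound 1 or moves toward compound 3. Also open, as far as these compounds go, is how a longer chain such as pentyl, or a shorter one such as ethyl, behaves on the same carbonyl carbon.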